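The compounds below may be only part of what the source reports. "The series", "measured", "known", "first", "only" and "open" are said of these compounds alone.

Compound 1, `O=C(CCCCC1CCSS1)NCc1cn(CCCOc2ccc3cc(-c4ccccc4)c(=O)oc3c2)nn1`, gives 29.8%
Compound 2, `O=C(CCCCC1CCSS1)NCc1cn(CCCCOc2ccc3cc(-c4ccc(Cl)cc4)c(=O)oc3c2)nn1`, gives 52%
Compound 3, `CCOC(=O)c1cc2ccc(OCCCCCn3cc(CNC(=O)CCCCC4CCSS4)nn3)cc2oc1=O`, gives 36.4%

These three compounds were compared in a functional assay on PC-12 cells (Rattus norvegicus) for cytotoxicity, read by MTT assay, with stated times of 3 h and 2 h, tested at 5 uM; a lower number here means a weaker effect, a higher number a stronger effect of the compound at the concentration tested. Among the three numbers, compound 3 stands second highest; its value and that of compound 1 lie within the scatter of each other, while the number for compound 2 sits beyond the scatter above compound 3. Compound 4, `O=C(CCCCC1CCSS1)NCc1cn(CCCCCOc2ccc3cc(-c4ccc(Cl)c(Cl)c4)c(=O)oc3c2)nn1`, has not yet been tested in this assay. It differs from compound 3 in one place: 3,4-dichlorophenyl in place of ethoxycarbonyl on an aromatic carbon. Within the data shown here, no measured pair in this set changes in the same way, so there is no measured step to lean on. Because compound 2 gives 52%, the expected step is upward and of modest size, a number 11.6 percentage points higher from compound 3 to compound 4 (beyond the scatter). Compound 4 is estimated at 48%, with a range from 30% to 66%.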

Compound 4, a percentage reported as activity, at one concentration (the size of the read-out at that concentration, not a potency): 54.8%
Compound 4: middle estimate off by 6.8 percentage points, on the low side, within the range that was stated.
By their numbers in this assay, from the lowest: compounds 1 and 3 (each within the scatter of the next); then compounds 2 and 4 (each within the scatter of the next).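

In this assay, putting 3,4-dichlorophenyl in place of ethoxycarbonyl on this aromatic carbon, two atoms from the ring oxygen, gives a number 18.4 percentage points higher from compound 3 to compound 4 (beyond the scatter). Among these compounds, this is the only single-place step in the set, and it shows that this position can carry an aromatic ring with no hydrogen-bond acceptors and lose none of the effect. No measurement at hand accounts for the rise. The compounds shown leave open how a carboxylic acid or an amine at this position would read, and whether the step would persist on a shorter chain.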